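Benzyl hydroxy to trifluoromethyl on the shared core

The source may hold more compounds than are shown below. What is called first, only, known or untested is meant among the compounds shown, and "the series" means these compounds.

Of the compounds shown here, three share a core and have been measured. In a functional assay on PC-3 cells (Homo sapiens) for antiproliferative activity, read by MTT assay, with a stated time of 48 h (on this read-out higher numbers stand for weaker inhibition and lower numbers for stronger inhibition), compound 3 `COc1ccc(CN(C(=O)CSc2nc3ccccc3s2)c2cc(OC)c(OC)c(OC)c2)cc1O` gives 2110 nM. Compound 1 `COc1ccc2nc(SCC(=O)N(Cc3ccc(OC)c(O)c3)c3cc(OC)c(OC)c(OC)c3)sc2c1` gives 4110 nM, and compound 2 `COc1cc(N(Cc2ccc(F)cc2)C(=O)CSc2nc3ccccc3s2)cc(OC)c1OC` gives 50800 nM. Compound 3 thus has the lowest number of the three, but the step of a 1.9-fold lower number from compound 1 to compound 3 (0.29 log units; within the scatter) is within the scatter, so no order between those two is claimed, whereas the step of a 24-fold lower number from compound 2 to compound 3 (1.38 log units; beyond the scatter) is beyond it and large.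

Compound 4 `COc1ccc(CN(C(=O)CSc2nc3ccccc3s2)c2cc(OC)c(OC)c(OC)c2)cc1C(F)(F)F` differs from compound 3 in one place: trifluoromethyl in place of hydroxy on an aromatic carbon. Of the measured steps, a 1.9-fold lower number from compound 1 to compound 3 (0.29 log units; within the scatter) concerns a methoxy elsewhere and bears little here. The step of a 24-fold lower number from compound 2 to compound 3 (1.38 log units; beyond the scatter) is the relevant one: compound 2 carries neither the hydroxy nor the methoxy on the benzyl ring and gives a far higher number. Compound 4 keeps the methoxy and loses only the hydroxy, so a rise in the number is expected, smaller than that step, namely a 4.3-fold higher number from compound 3 to compound 4 (0.63 log units; beyond the scatter). For compound 4 in this assay the estimate is 9000 nM, expected between 2500 nM and 35000 nM.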

Compound 4, half-maximal inhibitory concentration: > 80000 nM
Compound 4: a limit, no number; the forecaster's own chance of this, stated with the estimate: 5%; at least 8.8-fold (0.94 log units) between middle value and limit.
By their numbers in this assay, from the lowest: compounds 3 and 1 (each within the scatter of the next); then compound 2. At a limit, above all of these: compound 4.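

Compound 4 gives no number, only a limit: the limit of > 80000 nM in this assay, at which 1 of the 4 values shown sits. In this assay, hydroxy on this aromatic carbon, ortho to a methoxy group, was the only thing exchanged for trifluoromethyl, and that single change gives an at least 37-fold higher number from compound 3 to compound 4 (1.57 log units; beyond the scatter), whereas the earlier step from compound 2 to compound 3 changed hydroxy and methoxy together. Keeping the methoxy in 4-methoxy-3-(trifluoromethyl)phenyl therefore brings no demonstrated gain over 4-fluorophenyl, as the step reads an at least 1.5-fold higher number from compound 2 to compound 4 (0.19 log units; that floor lies within the scatter).

Still open, as far as these compounds go, is whether the rise comes from losing the hydroxy or from gaining the trifluoromethyl, which a plain hydrogen or an amino group on the same carbon would help to separate. From the compounds shown here alone, how far the true value of compound 4 lies past its limit also remains open.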